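From 4-isopropylpiperazin-1-yl to pyrrolidin-1-yl: solubility notes

A few compounds are considered here, and "the series" means these few. Any claim that something is new, unique, unknown or untested is made for them only; others in the source may bear on it.

Measured so far in a physicochemical assay for solubility, at pH 6.8; a lower number here means a less soluble compound, a higher number a more soluble compound:
- compound 1 `CN(C)Cc1ccc(-c2cnc(N)c(C(=O)NC[C@@](C)(O)C(F)(F)F)n2)cc1`: 510000 nM
- compound 2 `CC(C)N1CCN(Cc2ccc(-c3cnc(N)c(C(=O)NC[C@@](C)(O)C(F)(F)F)n3)cc2)CC1`: > 1000000 nM

Compound 2 is reported as > 1000000 nM in this assay, which is a limit of the assay and not a number. Its position is therefore known only as a limit.

The change to compound 3 `C[C@@](O)(CNC(=O)c1nc(-c2ccc(CN3CCCC3)cc2)cnc1N)C(F)(F)F` is pyrrolidin-1-yl in place of 4-isopropylpiperazin-1-yl on a saturated chain carbon bound to an aromatic carbon. It takes place on a saturated chain carbon bound to an aromatic carbon.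

Within the data shown here, one measured step bears on this: an at least 1.9-fold higher number from compound 1 to compound 2 (0.29 log units; that floor lies within the scatter), with dimethylamino in place of 4-isopropylpiperazin-1-yl at the start. Compound 3 also lacks the 4-isopropylpiperazin-1-yl, so compound 1, at 510000 nM, is the nearest guide. A modest move to a lower number is expected, of about the size of that step and possibly within the scatter. The expected step is an at least 1.6-fold lower number from compound 2 to compound 3 (0.22 log units; that floor lies within the scatter). Compound 3 is expected at 600000 nM, with an estimated range of 250000 nM to 1000000 nM.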

Compound 3, solubility: > 1000000 nM
Compound 3 ended at the assay's limit; the forecaster's own chance of this, stated with the estimate: 25%; at least 1.6-fold (0.22 log units) between middle value and limit.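

In this assay compound 3 gives > 1000000 nM as a limit of the assay and not a number. On the saturated chain carbon bound to an aromatic carbon, pyrrolidin-1-yl in place of dimethylamino reads as an at least 1.9-fold higher number from compound 1 to compound 3 (0.29 log units; that floor lies within the scatter) and so carries the same floor as the step to 4-isopropylpiperazin-1-yl, which leaves a real gap to compound 1 unproven for either group. The step from compound 2 to compound 3 cannot be read because both sit at this limit, so the two ring amines cannot be ranked at this position: the limit of > 1000000 nM in this assay, at which 2 of the 3 values shown sit.

Going by these compounds, how far compound 2 and compound 3 lie past the limit stays open. Also open, on these data alone, is whether a morpholin-4-yl ring or a carboxylic acid on this carbon would stay at the limit in this assay or fall back to a readable number.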